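Replacing the ethyl with a fluorinated phenyl on the ring nitrogen

A few compounds are considered here, and "the series" means these few. Any claim that something is new, unique, unknown or untested is made for them only; others in the source may bear on it.

Of the compounds shown here, three sharing one core have been tested in a functional assay on U2OS cells (Homo sapiens) for inhibition, read by CCK-8 assay, with a stated time of 72 h, tested at 1 uM; a higher number here means more inhibition at the concentration tested (going by the name of the read-out), a lower number less inhibition. Compound 1 `COc1ccc(OC)c(N2C(=O)CSC2c2cccc(C(=O)NCCCCc3ccccc3)c2)c1` gives 1%. Compound 2 `O=C(NCCCCc1ccccc1)c1cccc(C2SCC(=O)N2c2ccccc2)c1` gives 68%. Compound 3 `CCN1C(=O)CSC1c1cccc(C(=O)NCCCCc2ccccc2)c1` gives 13%, which places it second of the three: above compound 1 by a margin beyond the scatter, far beneath compound 2.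

The steps among them all concern the group on the amide-type nitrogen in the ring. The change a number 67 percentage points higher from compound 1 to compound 2 (beyond the scatter) is large, the change a number 12 percentage points higher from compound 1 to compound 3 (beyond the scatter) modest, and the change a number 55 percentage points lower from compound 2 to compound 3 (beyond the scatter) large and downward.

Compound 4 `O=C(NCCCCc1ccccc1)c1cccc(C2SCC(=O)N2c2cccc(F)c2)c1` is not yet measured. It differs from compound 3 in one place: 3-fluorophenyl in place of ethyl on an amide-type nitrogen in a ring. Among the compounds with values here, the step most relevant is the one from compound 2 to compound 3, since compound 4 restores a phenyl-type group carrying a single fluorine in place of ethyl. Reversing that large downward step suggests a large upward step, expected as a number 47 percentage points higher from compound 3 to compound 4 (beyond the scatter). Compound 4 is therefore expected to reach about 60%, within a range from 35% to 80%.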

Compound 4, a percentage reported as inhibition, at one concentration (the size of the read-out at that concentration, not a potency): 39%
For compound 4 the middle estimate is 21 percentage points above the measured one; measured number inside the range.
By their numbers in this assay, from the lowest: compound 1; then compound 3; then compound 4; then compound 2.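

A single fluorine on the phenyl ring is a smaller change than any seen before at this ring nitrogen, yet it still matters in this assay (a number 29 percentage points lower from compound 2 to compound 4 (beyond the scatter)). The 3-fluorophenyl group keeps part of the advantage of phenyl over ethyl (a number 26 percentage points higher from compound 3 to compound 4 (beyond the scatter)) and also stands well clear of 2,5-dimethoxyphenyl (a number 38 percentage points higher from compound 1 to compound 4 (beyond the scatter)), so what the phenyl ring carries decides much of the outcome, and compound 1 goes against any simple rule that a phenyl-type group beats ethyl. Nothing available explains these differences.

Still open, from the compounds shown here alone, is how a phenyl ring carrying chlorine, a methyl group or a carboxylic acid in place of the fluorine would compare with compound 4. Also open, going by these compounds, is how a longer chain such as butyl would compare with the ethyl of compound 3.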